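Methylating the Sulfonamide Nitrogen: From Compound 2 to Compound 3

The source may report more compounds than this note shows. Statements on the series, on what has been measured and on what is new or still open speak of the compounds shown alone.

compound 1 `CCCN(CCC)c1c([N+](=O)[O-])cc(S(=O)(=O)Nc2ccc(Cl)cc2)cc1[N+](=O)[O-]` 10000 nM
compound 2 `CCCN(CCC)c1c([N+](=O)[O-])cc(S(=O)(=O)Nc2cccc(C)c2)cc1[N+](=O)[O-]` 16000 nM

In a functional assay on J774 cells (Mus musculus) for cytotoxicity (a higher number here means a weaker inhibitor, a lower number a stronger inhibitor), compound 1 gives 10000 nM and compound 2 gives 16000 nM. Compound 2 holds the higher of the two numbers, yet the step of a 1.6-fold higher number from compound 1 to compound 2 (0.20 log units; within the scatter) stays within the scatter, so the two cannot be ordered. Compound 3 `CCCN(CCC)c1c([N+](=O)[O-])cc(S(=O)(=O)N(C)c2ccccc2)cc1[N+](=O)[O-]` differs from compound 2 by methyl(phenyl)amino in place of (3-methylphenyl)amino on a sulfonyl sulfur. Going by the values given here, the only measured step, a 1.6-fold higher number from compound 1 to compound 2 (0.20 log units; within the scatter), varies the aryl group and leaves the sulfonamide nitrogen untouched, so it bears only loosely on this change. Compound 3 is therefore expected to show no change at the digits printed from compound 2 to compound 3 (within the scatter), with no step beyond the scatter. Compound 3 is estimated at 16000 nM, within 5000 nM to 50000 nM.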

Compound 3, half-maximal inhibitory concentration: 11000 nM
For compound 3 the middle estimate is 1.5-fold (0.16 log units) above the measured one; measured number inside the range.
By their numbers in this assay, from the lowest: compounds 1, 3 and 2 (each within the scatter of the next).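

In this change the methyl moves from the ring to the sulfonamide nitrogen, removing the hydrogen-bond donor there, and this assay separates neither pair (a 1.5-fold lower number from compound 2 to compound 3 (0.16 log units; within the scatter); a 1.1-fold higher number from compound 1 to compound 3 (0.04 log units; within the scatter)). So, among these three compounds, a sulfonyl sulfur bearing methyl(phenyl)amino reads no differently from one bearing either substituted arylamino group. No evidence is available to explain this result. As far as these compounds go, whether a longer chain such as ethyl or benzyl on that nitrogen, or a carboxylic acid on the aryl ring, would shift the number beyond the scatter remains open.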